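Working notes: from compound 2 to compound 4

This account rests on a few compounds, and the source may have more. Where it says the series, first, only, none or still open, it means among the compounds named here.

The three measured compounds share one core carrying a trifluoromethyl and a phenylsulfonyl group and differ only at the nitrogen of the ring amine. Compound 1 `O=C(c1ccccc1)N1CCC(NS(=O)(=O)c2cc(S(=O)(=O)c3ccccc3)ccc2C(F)(F)F)CC1` gives 250 nM in an assay on U2OS cells for inhibition of secreted frizzled-related protein 1 (Homo sapiens), read by a luciferase reporter, with a stated time of 18 h; a higher number here means that more compound is needed for the effect, a lower number that less compound is needed. Compound 2 `O=C(c1cccc(Cl)c1)N1CCC(NS(=O)(=O)c2cc(S(=O)(=O)c3ccccc3)ccc2C(F)(F)F)CC1` gives 870 nM, and compound 3 `O=S(=O)(NC1CCN(S(=O)(=O)c2ccccc2)CC1)c1cc(S(=O)(=O)c2ccccc2)ccc1C(F)(F)F` gives 210 nM. Compound 2 stands with the highest of the three numbers: a 3.5-fold higher number from compound 1 to compound 2 (0.54 log units; beyond the scatter) and a 4.1-fold lower number from compound 2 to compound 3 (0.62 log units; beyond the scatter), whereas a 1.2-fold lower number from compound 1 to compound 3 (0.08 log units; within the scatter).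

Compound 4 `O=C(C1CCNCC1)N1CCC(NS(=O)(=O)c2cc(S(=O)(=O)c3ccccc3)ccc2C(F)(F)F)CC1` is not yet measured. Its change from compound 2 is as follows: piperidin-4-yl in place of 3-chlorophenyl on a carbonyl carbon. Within the data shown here, two measured steps bear on this. The chloro that entered in a 3.5-fold higher number from compound 1 to compound 2 (0.54 log units; beyond the scatter) is lost again here, and a 4.1-fold lower number from compound 2 to compound 3 (0.62 log units; beyond the scatter) shows that replacing the (3-chlorophenyl)carbonyl returns the number to the level of compounds 1 and 3. Nothing measured shows how a piperidin-4-yl on the carbonyl carbon fares, so the return is expected to be only partial. A modest step downward is therefore expected, a 2.2-fold lower number from compound 2 to compound 4 (0.34 log units; beyond the scatter). For compound 4 the expected value in this assay is 400 nM, with a range from 100 nM to 1600 nM.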

Compound 4, half-maximal effective concentration: 150 nM
Beside the measured number, compound 4's estimate is 2.7-fold (0.43 log units) above it; low and high end bracket the measured number.
By their numbers in this assay, from the lowest: compounds 4, 3 and 1 (each within the scatter of the next); then compound 2.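

In this assay, the carbonyl carbon on the amide-type ring nitrogen accepts a non-aromatic ring with a hetero atom, which compound 1, compound 2 and compound 3 could not show, since each carries an aromatic ring there or on a sulfonyl. The exchange of 3-chlorophenyl for piperidin-4-yl gives the step (a 5.8-fold lower number from compound 2 to compound 4 (0.76 log units; beyond the scatter)), so the high number of compound 2 does not persist with this group, while compound 4 sits level with the other two (a 1.7-fold lower number from compound 1 to compound 4 (0.22 log units; within the scatter); a 1.4-fold lower number from compound 3 to compound 4 (0.15 log units; within the scatter)), both steps within the scatter, so that piperidin-4-yl, phenyl on the carbonyl carbon and phenylsulfonyl on the ring nitrogen cannot be told apart here. No data at hand bear on what lies behind the step from the 3-chlorophenyl group.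

The compounds shown leave open whether the ring nitrogen of piperidin-4-yl contributes at all, which a cyclohexyl on the same carbonyl carbon would test directly. Also open, on these data alone, is how a carboxylic acid, or a longer chain ending in an amine, would read on that carbonyl carbon.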